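The source may report more compounds than this note shows. Statements on the series, on what has been measured and on what is new or still open speak of the compounds shown alone.

Of the compounds shown here, three built on one shared core have been tested in a functional assay on MCF7 cells (Homo sapiens) for cytotoxicity, read by MTT assay, with a stated time of 24 h; a lower number here means a stronger inhibitor, a higher number a weaker inhibitor. Compound 1 `Cc1cc(O)c(C(=O)/C=C/c2ccccc2)c(-c2ccccc2)c1C(=O)/C=C/c1ccccc1` gives 10000 nM in this assay, a weak result. Compound 2 `COc1ccc(/C=C/C(=O)c2c(C)cc(O)c(C(=O)/C=C/c3ccc(OC)cc3)c2-c2ccccc2)cc1` is recorded in this assay simply as "not active" (no number reported), with no number attached. Compound 3 `COc1ccc(/C=C/C(=O)c2c(C)cc(O)c(C(=O)/C=C/c3ccc(OC)cc3)c2-c2ccc(Br)cc2)cc1` is likewise recorded in this assay as "not active" (no number reported), again without a number. So compound 3 stands without a figure of its own; it sits alongside compound 2, the other compound for which only the word and no value was reported, and nothing in the numbers separates the two.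

Compound 4 `COc1ccc(/C=C/C(=O)c2c(C)cc(O)c(C(=O)/C=C/c3ccc(OC)cc3)c2-c2ccc(OCc3ccccc3)cc2)cc1` arises from compound 3 by a single change: benzyloxy in place of bromo on an aromatic carbon, in words a benzyloxy in place of a bromo on an aromatic carbon. For the measured compounds named here, no measured pair shows what this exchange does in this assay, so there is no step to lean on. The expectation is that compound 4 remains weak, with no change beyond the usual scatter, and the estimate for compound 4 in this assay is 30000 nM, within 10000 nM to 100000 nM, with a real chance that only inactivity is reported.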

Compound 4, half-maximal inhibitory concentration: 30000 nM
Compound 4: the middle estimate sits on the measured number at the digits printed; the measured number falls inside the stated range.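

For the compounds shown here, compound 3 is recorded only as "not active" in this assay, so no step to compound 4, at 30000 nM, can be read. From the compounds shown here alone, what benzyloxy in place of bromo does on its own stays open. No supporting data bear on the result of compound 4.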